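Adding a side chain to the core of compound 1

A few compounds are considered here, and "the series" means these few. Any claim that something is new, unique, unknown or untested is made for them only; others in the source may bear on it.

Measured in a functional assay on MDA-MB-231 cells (Homo sapiens) for antiproliferative activity, read by MTT assay, with a stated time of 48 h; a higher number here means a weaker inhibitor, a lower number a stronger inhibitor:
Compound 1 `C=CS(=O)(=O)N1CCN(c2ncnc3sc(-c4ccc(OC)nc4)cc23)CC1` gives 9270 nM
Compound 2 `C=CS(=O)(=O)N1CCN(c2ncnc3sc(-c4cc(Br)cnc4F)cc23)CC1` gives 24100 nM
Compound 3 `C=CS(=O)(=O)N1CCN(c2ncnc3sc(-c4cn(C)nc4C(F)(F)F)cc23)CC1` gives 10400 nM

Exchanging one aromatic group for another gives a 1.1-fold higher number from compound 1 to compound 3 (0.05 log units; within the scatter), while a different exchange gives a 2.6-fold higher number from compound 1 to compound 2 (0.41 log units; beyond the scatter). Compound 1 therefore shares the stronger end of this small set. Compound 4 `C=CS(=O)(=O)N1CCN(c2nc(OC[C@H]3CCCN3C)nc3sc(-c4ccc(OC)nc4)cc23)CC1` keeps the aromatic group of compound 1 and changes the core instead: (1-methylpyrrolidin-2-yl)methoxy in place of hydrogen on an aromatic carbon, with (1-methylpyrrolidin-2-yl)methoxy in place of hydrogen on an aromatic carbon, between two ring nitrogen atoms. Among the compounds with values here, no measured step touches this place, so those steps show only how far one change has moved the number here, and the direction remains open. In this assay, the expected step is no larger than the scatter: a 1.3-fold lower number from compound 1 to compound 4 (0.12 log units; within the scatter). Compound 4 is estimated at 7000 nM, with an expected range of 2000 nM to 20000 nM.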

Compound 4, half-maximal inhibitory concentration: 3560 nM
The estimate for compound 4 lay 2.0-fold (0.29 log units) above the measured number; the measured number falls inside the stated range.
By their numbers in this assay, from the lowest: compound 4; then compounds 1 and 3 (each within the scatter of the next); then compound 2.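

Until now only the aromatic group had changed; here the core itself changes, at the aromatic carbon between two ring nitrogen atoms. In this assay, (1-methylpyrrolidin-2-yl)methoxy in place of hydrogen at this carbon gives a stronger inhibitor (a 2.6-fold lower number from compound 1 to compound 4 (0.42 log units; beyond the scatter)), so this position accepts a side chain carrying a ring. Nothing shown here gives a reason for this shift.

As far as these compounds go, whether a plain methoxy group, an open-chain 2-(dimethylamino)ethoxy group or the mirror-image side chain would serve equally stays open. So does whether this side chain would lower the number for compound 2 or compound 3 as well.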